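Chain extension toward a conjugated acid in the imidazole series

The compounds below may be only part of what the source reports. "The series", "measured", "known", "first", "only" and "open" are said of these compounds alone.

Within the data shown here, compound 2 `O=C(O)CCCCc1cccc2cncn12` gives 41 nM in an assay for inhibition of Thromboxane-A synthase (Homo sapiens) (a higher number here means a weaker inhibitor, a lower number a stronger inhibitor), the highest of the two numbers so far; compound 1 `O=C(O)CCCCCCc1cccc2cncn12` gives 5.2 nM. Compound 3 `O=C(O)/C=C/CCCc1cccc2cncn12` differs from compound 2 by 2-carboxyethenyl in place of carboxymethyl on a saturated chain carbon, three bonds along the chain from an aromatic carbon. Among the measured compounds shown here, the only step that bears on this is a 7.9-fold higher number from compound 1 to compound 2 (0.90 log units; beyond the scatter), where shortening the chain raised the number. Compound 3 lengthens the chain again, though with a double bond and not to the full length of compound 1, so a drop is expected, estimated as a 2.7-fold lower number from compound 2 to compound 3 (0.44 log units; beyond the scatter). Compound 3 is therefore expected at 15 nM, within 5 nM to 45 nM.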

Compound 3, half-maximal inhibitory concentration: 4.8 nM
Beside the measured number, compound 3's estimate is 3.1-fold (0.49 log units) above it; measured number below the stated range.
By their numbers in this assay, from the lowest: compounds 3 and 1 (each within the scatter of the next); then compound 2.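

In this assay, 2-carboxyethenyl in place of carboxymethyl on a saturated chain carbon, three bonds along the chain from an aromatic carbon, gives a step (an 8.5-fold lower number from compound 2 to compound 3 (0.93 log units; beyond the scatter)) of about the size of the earlier one (a 7.9-fold higher number from compound 1 to compound 2 (0.90 log units; beyond the scatter)), now in the opposite direction. At this place, 2-carboxyethenyl and 3-carboxypropyl cannot be told apart (a 1.1-fold lower number from compound 1 to compound 3 (0.03 log units; within the scatter)). Nothing at hand accounts for this result.

Open, as far as these compounds go, is what the double bond itself contributes, which a saturated chain of the length in compound 3 would settle. Also open, from the compounds shown here alone, is how a longer chain with a double bond, or an ester in place of the carboxylic acid, would read.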